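A few compounds are considered here, and "the series" means these few. Any claim that something is new, unique, unknown or untested is made for them only; others in the source may bear on it.

Going by the values given here, compound 2 `Cc1ccccc1C(=O)Nc1ccc(S(=O)(=O)NC2CCN(C(=O)N(C)C)CC2)c2ccccc12` gives 1.6 nM in an assay on L1.2 cells for binding affinity to C-C chemokine receptor type 8 (Homo sapiens) (on this read-out higher numbers stand for weaker inhibition and lower numbers for stronger inhibition), the lower of the two numbers so far; compound 1 `Cc1ccccc1C(=O)Nc1ccc(S(=O)(=O)NC2CCN(C(=O)NC(C)C)CC2)c2ccccc12` gives 77.7 nM. The step of a 49-fold lower number from compound 1 to compound 2 (1.69 log units; beyond the scatter) shows how strongly the group on the carbonyl carbon moves this assay. Compound 3 `CCN(CC)CCCC(=O)N1CCC(NS(=O)(=O)c2ccc(NC(=O)c3ccccc3C)c3ccccc23)CC1` carries 3-(diethylamino)propyl in place of dimethylamino on a carbonyl carbon. Among the compounds with values here, no measured step covers a change of this kind, so only the size of the preceding step bears on it, and that step argues a shift well beyond the scatter is possible in either direction. A moderate loss is expected, a 3.1-fold higher number from compound 2 to compound 3 (0.49 log units; beyond the scatter). Compound 3 is therefore estimated at 5 nM, within 1 nM to 40 nM.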

Compound 3, inhibition constant: 567 nM
For compound 3 the middle estimate is 110-fold (2.05 log units) below the measured one; measured number outside the range, above it.
By their numbers in this assay, from the lowest: compound 2; then compound 1; then compound 3.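

In this assay the group on the carbonyl carbon can cost far more than the earlier pair indicated: 3-(diethylamino)propyl in place of dimethylamino gives a 350-fold higher number from compound 2 to compound 3 (2.55 log units; beyond the scatter) as the largest step in the series. Against isopropylamino, the same chain still gives a 7.3-fold higher number from compound 1 to compound 3 (0.86 log units; beyond the scatter) and so is the least favoured of the three groups here. No measurement on hand accounts for this loss.

Compound 3 changes the chain and the atom bonded to the carbonyl carbon at once, and these two changes remain unseparated. Going by these compounds, whether diethylamino bonded directly to the carbonyl carbon, or a plain butyl chain, keeps the low number of compound 2 stays open.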